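This account rests on a few compounds, and the source may have more. Where it says the series, first, only, none or still open, it means among the compounds named here.

Measured values in a physicochemical assay for lipophilicity (a higher number here means a more lipophilic compound, a lower number a more polar compound), so far:
- compound 1 (`CC(C)OC[C@H](Oc1ncnc2c1cnn2-c1ccccc1Cl)C(=O)Nc1ccc(C#N)cn1`), value (3.5)
- compound 2 (`Cc1ccc(NC(=O)[C@H](COC(C)C)Oc2ncnc3c2cnn3-c2ccccc2Cl)nc1`), value (3.9)
- compound 3 (`CC(C)OC[C@H](Oc1ncnc2c1cnn2-c1ncccc1Cl)C(=O)Nc1ccccn1`), value (2.5)

Compound 3 has the lowest of these three values, and compounds 1 and 2 both stand clearly higher. Compound 4 (`CC(C)OC[C@H](Oc1ncnc2c1cnn2-c1ccccc1Cl)C(=O)Nc1ccccn1`) has not yet been measured. It departs from compound 3 in one place (2-chlorophenyl in place of 3-chloropyridin-2-yl on an aromatic nitrogen), with 2-chlorophenyl in place of 3-chloropyridin-2-yl on an aromatic nitrogen.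

Going by the values given here, only one measured step is available (a number 0.40 log units higher from compound 1 to compound 2 (beyond the scatter)). It is methyl in place of cyano on an aromatic carbon, a different place from the change at hand, so it bears on this change only indirectly. It does show how far apart two compounds carrying 2-chlorophenyl can lie. Compound 4 shares that group with compound 1 (3.5) and compound 2 (3.9) but carries neither the cyano nor the methyl, so it is expected to fall near those two. In this assay, among the compounds with values here, the expected change is a rise (a number 0.90 log units higher from compound 3 to compound 4 (beyond the scatter)), larger than the one measured step. Compound 4 is estimated at 3.4 within an expected range from 3 to 3.8 until a measurement is available.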

Compound 4, distribution coefficient: 3.5
Compound 4: the middle estimate sits 0.10 log units below what was measured; measured number inside the range.
By their numbers in this assay, from the lowest: compound 3; then compounds 1 and 4 (each within the scatter of the next); then compound 2.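

In this assay, going by these compounds alone, 2-chlorophenyl in place of 3-chloropyridin-2-yl on the aromatic nitrogen of the five-membered ring gives a number 1.00 log units higher from compound 3 to compound 4 (beyond the scatter), the first reading of a change at this position, where a ring with one hetero atom gives way to a ring of carbon only. Compound 4 also gives the other end of the molecule a reference carrying hydrogen: hydrogen in place of methyl on the aromatic carbon gives a number 0.40 log units lower from compound 2 to compound 4 (beyond the scatter), while hydrogen in place of cyano gives no change at the digits printed from compound 1 to compound 4 (within the scatter), so of these two groups only the methyl reads apart from hydrogen. Nothing measured here accounts for the size of any of these steps.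

Within the data shown here, compound 3 and compound 4 are the only pair that differ at this position, so it stays open whether the step keeps its size when the other end carries the methyl or the cyano. Nor do these compounds show how this assay would read with an amine or a carboxylic acid on the ring at this position.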